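A few compounds are considered here, and "the series" means these few. Any claim that something is new, unique, unknown or untested is made for them only; others in the source may bear on it.

Working notes on the series in a functional assay on HL-60 cells (Homo sapiens) for antiproliferative activity, with a stated time of 24 h; a lower number here means a stronger inhibitor, a higher number a weaker inhibitor. Compound 1 (`NC(=O)c1c(NC(=O)c2ccccc2Cl)sc2c1CCN(Cc1ccccc1F)C2`) gives 21800 nM, and compound 2 (`NC(=O)c1c(NC(=O)c2ccccc2Cl)sc2c1CCN(Cc1ccc(Cl)cc1)C2`) gives 22500 nM. For compound 3 (`NC(=O)c1c(NC(=O)c2ccc(C(F)(F)F)cc2)sc2c1CCN(Cc1ccccc1F)C2`) the assay reports only a limit, > 50000 nM, and no number.

Compound 4 (`NC(=O)c1c(NC(=O)c2ccc(C(F)(F)F)cc2)sc2c1CCN(Cc1ccc(Cl)cc1)C2`) carries 4-chlorophenyl in place of 2-fluorophenyl on a saturated chain carbon bound to an amine nitrogen in a ring. The same exchange has been measured on one pair only, with 2-chlorophenyl on the carbonyl carbon: a 1.0-fold higher number from compound 1 to compound 2 (0.01 log units; within the scatter). The other measured step bears on the level rather than on the exchange. Placing 4-(trifluoromethyl)phenyl on the carbonyl carbon instead of 2-chlorophenyl gives an at least 2.2-fold higher number from compound 1 to compound 3 (0.36 log units; beyond the scatter), and compound 4 keeps that group. With one flat pair as the guide, no step beyond the scatter is expected in this assay, in either direction. The expected step is a step that the limit leaves unreadable from compound 3 to compound 4. Compound 4 is estimated at 55000 nM, with an expected range of 30000 nM to 90000 nM, and may well report only a limit.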

Compound 4, half-maximal inhibitory concentration: > 50000 nM
Compound 4: only a limit was reported; the forecaster's own chance of this, stated with the estimate: 70%; the middle value lies beyond the limit too.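

In this assay the value of compound 4, > 50000 nM, is a limit and not a number, and compound 3 also has only a limit, so the exchange of 2-fluorophenyl for 4-chlorophenyl cannot be read at this carbonyl substituent. The new information concerns the carbonyl carbon: with 4-chlorobenzyl held constant, 4-(trifluoromethyl)phenyl in place of 2-chlorophenyl gives an at least 2.2-fold higher number from compound 2 to compound 4 (0.34 log units; beyond the scatter). The change now points the same way in both matched pairs: the same change on two cores in this assay, an at least 2.2-fold higher number (0.36 log units; beyond the scatter) from compound 1 to compound 3 and an at least 2.2-fold higher number (0.34 log units; beyond the scatter) from compound 2 to compound 4; the limit leaves it open whether they differ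

As far as these compounds go, how far the 4-(trifluoromethyl)phenyl compounds lie past the measurable range stays open: the limit of > 50000 nM in this assay, at which 2 of the 4 values shown sit. Also open is whether an amine or a carboxylic acid in place of 4-chlorophenyl on the saturated chain carbon bound to an amine nitrogen in a ring would move the number beyond the scatter.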